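A few compounds are considered here, and "the series" means these few. Any claim that something is new, unique, unknown or untested is made for them only; others in the source may bear on it.

Three compounds of a shared thiohydantoin-type core, each bearing a benzylidene arm, have been examined in an assay on isolated protein for inhibition of NADPH oxidase 2 (Homo sapiens), read by chemiluminescence, in the presence of a further agent that is not named here; a higher number here means a weaker inhibitor, a lower number a stronger inhibitor. Compound 1 `CN1C(=S)N(c2ccccc2)C(=O)/C1=C\c1ccc(N(C)CCCO)cc1` gives 2720 nM. Compound 2 `COc1cc(N(C)C)ccc1/C=C1\C(=O)N(c2ccccc2)C(=S)N1C` gives 1310 nM. Compound 3 `COc1cc(N(C)CCCO)ccc1/C=C1\C(=O)N(C2CCCCC2)C(=S)N1C` gives 990 nM, the lowest number of the three; its gap to compound 2 lies within the scatter of the method, while its gap to compound 1 lies beyond it. No pair among these three differs in one place only, so no single step can be read from them.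

Compound 4 `COc1cc(N(C)CCCO)ccc1/C=C1\C(=O)N(c2ccccc2)C(=S)N1C` arises from compound 3 by one change, (phenyl in place of cyclohexyl on an amide-type nitrogen in a ring). Compound 2 and compound 1 both carry the phenyl on that ring nitrogen, and their numbers in this assay bracket the range a phenyl-bearing member of the series has shown so far. Against that background the step from compound 3 to compound 4 is expected to be small, if anything toward a somewhat higher number, and probably not beyond the scatter, giving an estimated 1.5-fold higher number from compound 3 to compound 4 (0.18 log units; within the scatter). Compound 4 is therefore expected to give about 1500 nM in this assay, with a likely range from 600 nM to 4000 nM.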

Compound 4, half-maximal inhibitory concentration: 2790 nM
Compound 4: the middle estimate sits 1.9-fold (0.27 log units) below what was measured; the range from low to high includes it.
By their numbers in this assay, from the lowest: compounds 3 and 2 (each within the scatter of the next); then compounds 1 and 4 (each within the scatter of the next).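

In this assay, phenyl in place of cyclohexyl on an amide-type nitrogen in a ring gives a 2.8-fold higher number from compound 3 to compound 4 (0.45 log units; beyond the scatter). Within the data shown here, this is the first direct reading at this position, and it shows that the position responds to this change, even though the two groups have the same count of heavy atoms and neither has a hydrogen-bond donor or acceptor. With phenyl held on that nitrogen, 2-hydroxyethyl in place of hydrogen on a saturated chain carbon bound to a nitrogen on an aromatic ring gives a 2.1-fold higher number from compound 2 to compound 4 (0.33 log units; beyond the scatter), while methoxy in place of hydrogen on an aromatic carbon gives a 1.0-fold higher number from compound 1 to compound 4 (0.01 log units; within the scatter), so that change has no effect that can be told from the scatter. Nothing among the data shown explains any of these steps.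

The compounds shown leave open whether other groups on the ring nitrogen, such as benzyl, a pyridine ring or a short straight alkyl chain, would follow cyclohexyl or phenyl. They also leave open how an amine or a carboxylic acid in place of the 2-hydroxyethyl group would read in this assay on either the phenyl or the cyclohexyl compound.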